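The source may hold more compounds than are shown below. What is called first, only, known or untested is meant among the compounds shown, and "the series" means these compounds.

Working notes on the series. Among the compounds with values here, compound 2 `COc1ccc(-c2csc(NC(=O)COc3ccc(C(=O)c4ccc(F)cc4)cc3C)n2)cc1` gives the lowest of the two numbers so far in a functional assay on DLA cells (Mus musculus) for cytotoxicity, read by trypan blue exclusion, with a stated time of 48 h; on this read-out higher numbers stand for weaker inhibition and lower numbers for stronger inhibition: compound 2 gives 5000 nM, and its nearest neighbour, compound 1 `COc1ccc(-c2csc(NC(=O)COc3ccc(C(=O)c4ccccc4)cc3C)n2)cc1`, gives 24200 nM. Within the data shown here, the one step between them, a 4.8-fold lower number from compound 1 to compound 2 (0.68 log units; beyond the scatter), is the only step in the set. Compound 3 `COc1ccc(-c2csc(NC(=O)COc3ccc(C(=O)c4cccc(Br)c4)cc3C)n2)cc1` is not yet measured; it differs from compound 2 by 3-bromophenyl in place of 4-fluorophenyl on a carbonyl carbon. Among the measured compounds shown here, no measured step covers a bromine in place of a fluorine on that phenyl, nor a change of where the halogen sits on it, so the step from compound 1 to compound 2 bears on it only in that both compounds carry a halogen on this phenyl. The expectation is therefore a step of about a 1.2-fold higher number from compound 2 to compound 3 (0.08 log units; within the scatter), with no clear direction beyond the scatter. For compound 3 the estimated value in this assay is 6000 nM, expected to lie between 2000 nM and 18000 nM.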

Compound 3, half-maximal inhibitory concentration: 35400 nM
For compound 3 the middle estimate is 5.9-fold (0.77 log units) below the measured one; the measured number lies above the stated range.
By their numbers in this assay, from the lowest: compound 2; then compounds 1 and 3 (each within the scatter of the next).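

On the phenyl on the carbonyl carbon, a halogen alone does not bring the lower number: in this assay the change from 4-fluorophenyl to 3-bromophenyl gives a 7.1-fold higher number from compound 2 to compound 3 (0.85 log units; beyond the scatter) and so separates the two halogenated compounds. Against the unsubstituted phenyl, the bromine gives a 1.5-fold higher number from compound 1 to compound 3 (0.17 log units; within the scatter) and leaves compound 3 not distinguishable from compound 1, so the gain seen with 4-fluorophenyl is not shared by 3-bromophenyl. Nothing available explains this difference between the two halogenated phenyl groups.

The element and its place on the ring change together from compound 2 to compound 3, so the compounds shown cannot tell which of the two matters. Also open, on these data alone, is how a chlorine, a methoxy group or a nitrile on this phenyl would read.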